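Coumarin series: chloromethyl replacing carboxymethoxy, monoamine oxidase A

The compounds below may be only part of what the source reports. "The series", "measured", "known", "first", "only" and "open" are said of these compounds alone.

Measured in an assay on isolated protein (strain Sprague-Dawley) for inhibition of Amine oxidase [flavin-containing] A (Rattus norvegicus), read by spectrophotometry, with a stated time of 5 min, tested at 10 uM; on this read-out lower numbers stand for less inhibition and higher numbers for more inhibition at the one concentration tested (going by the name of the read-out):
compound 1 `CCCOc1cc(=O)oc2cc(OCc3ccccc3)ccc12`: 0%
compound 2 `CCOc1cc(=O)oc2cc(OCc3cccc(F)c3)ccc12`: 25%
compound 3 `O=C(O)COc1cc(=O)oc2cc(OCc3cccc(Cl)c3)ccc12`: 0%

Compound 3 sits level with compound 1 at the digits shown, the two together forming the lowest of the three numbers; compound 2 stands higher than compound 3 by a gap beyond the scatter. Compound 4 `O=c1cc(CCl)c2ccc(OCc3cccc(Cl)c3)cc2o1` remains to be measured in this assay. Against compound 3 it carries one change: chloromethyl in place of carboxymethoxy on an aromatic carbon. Within the data shown here, no measured pair in this set isolates that change, so the data give no direction for it. The expectation is a moderate upward step from compound 3 to compound 4, a number 20 percentage points higher from compound 3 to compound 4 (beyond the scatter), with wide uncertainty. Compound 4 is estimated at 20% in this assay, in a range from 0% to 55%.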

Compound 4, a percentage reported as inhibition, at one concentration (the size of the read-out at that concentration, not a potency): 21%
Beside the measured number, compound 4's estimate is 1 percentage points below it; the measured number falls inside the stated range.
By their numbers in this assay, from the lowest: compounds 1 and 3 (each within the scatter of the next); then compounds 4 and 2 (each within the scatter of the next).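

Chloromethyl in place of carboxymethoxy on this aromatic carbon gives a number 21 percentage points higher from compound 3 to compound 4 (beyond the scatter) in this assay and is the first change at this position that can be read alone. With the rest of the structure unchanged, this position therefore affects the read-out, although the step is modest. No measurement here explains the step.

Still open, from the compounds shown here alone, is whether a methyl, a hydroxymethyl or an aminomethyl group at this position would give a similar number. Also open, going by these compounds, is whether the step would carry over to other benzyl ether substituents on the shared core.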